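Trifluoromethylsulfonyl in Place of Ethylsulfonyl: Cytotoxicity Expectation

The compounds below may be only part of what the source reports. "The series", "measured", "known", "first", "only" and "open" are said of these compounds alone.

Compound 1 `Cc1cc(NC(=O)c2cc(C(F)(F)F)cc(C(F)(F)F)c2)ccc1NS(=O)(=O)C(F)(F)F` gives 182000 nM in an ADME assay on HEK293 cells (Homo sapiens) for cytotoxicity, read by MTT assay, with a stated time of 48 h; on this read-out lower numbers stand for stronger inhibition and higher numbers for weaker inhibition.
Compound 2 `CS(=O)(=O)Nc1ccc(NC(=O)c2cc(C(F)(F)F)cc(C(F)(F)F)c2)cc1F` sits at the limit > 250000 nM in this assay.
Compound 3 `CCS(=O)(=O)Nc1ccc(NC(=O)c2cc(C(F)(F)F)cc(C(F)(F)F)c2)cc1F` sits at the limit > 250000 nM in this assay.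

Compound 3 stands only at a limit of this assay, not at a number, as does compound 2, so a step that the two limits leave unreadable from compound 2 to compound 3 cannot be read; both rest at the limit of > 250000 nM in this assay, at which 2 of the 3 values shown sit. Compound 4 `O=C(Nc1ccc(NS(=O)(=O)C(F)(F)F)c(F)c1)c1cc(C(F)(F)F)cc(C(F)(F)F)c1` arises from compound 3 by trifluoromethyl in place of ethyl on a sulfonyl sulfur. Going by the values given here, no measured step covers this change directly. Compound 1 carries the same (trifluoromethyl)sulfonyl group and gives a number near the top of the measured range. On that footing compound 4 is expected to show an at least 1.3-fold lower number from compound 3 to compound 4 (0.14 log units; that floor lies within the scatter), no readable change beyond the limit. Compound 4 is estimated at 180000 nM, within 80000 nM to 300000 nM.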

Compound 4, half-maximal inhibitory concentration: 164000 nM
For compound 4 the middle estimate is 1.1-fold (0.04 log units) above the measured one; measured number inside the range.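

In this assay, trifluoromethyl on the sulfonyl sulfur gives a readable number where the alkyl groups gave none, with an at least 1.5-fold lower number from compound 3 to compound 4 (0.18 log units; that floor lies within the scatter) and an at least 1.5-fold lower number from compound 2 to compound 4 (0.18 log units; that floor lies within the scatter). Both steps are only floors, since compound 2 and compound 3 each stand at a limit and not at a number: the limit of > 250000 nM in this assay, at which 2 of the 4 values shown sit. Fluoro in place of methyl on the aromatic carbon shows no separable effect, with a 1.1-fold lower number from compound 1 to compound 4 (0.05 log units; within the scatter).

From the compounds shown here alone, the true size of the two floored steps remains open. So does what a longer chain or an amine on the sulfonyl sulfur would give.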